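Ester to acid at the pyridyl substituent of an oxazole ketone

The source may report more compounds than this note shows. Statements on the series, on what has been measured and on what is new or still open speak of the compounds shown alone.

Compound 1 `COC(=O)c1cccc(-c2cnc(C(=O)CCc3ccc(OC4CCN(C(=O)OC(C)(C)C)CC4)cc3)o2)n1` is the weaker of the two measured compounds: in an assay for inhibition of Fatty-acid amide hydrolase 1 (Rattus norvegicus) (on this read-out higher numbers stand for weaker inhibition and lower numbers for stronger inhibition), compound 1 gives 32 nM, while compound 2 `COC(=O)c1ccc(-c2cnc(C(=O)CCc3ccc(-c4ccccc4)cc3)o2)cn1` gives 0.6 nM, a gap beyond the scatter. Compound 3 `CC(C)(C)OC(=O)N1CCC(Oc2ccc(CCC(=O)c3ncc(-c4cccc(C(=O)O)n4)o3)cc2)CC1` differs from compound 1 by hydrogen in place of methyl on an oxygen next to a carbonyl group. Going by the values given here, no measured pair shows this change, so its size is unknown; the loss of the methyl is expected to weaken binding moderately, and the step from compound 1 to compound 3 is estimated at a 3.1-fold higher number from compound 1 to compound 3 (0.49 log units; beyond the scatter). Compound 3 is therefore expected to give about 100 nM, within 20 nM to 500 nM.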

Compound 3, inhibition constant: 120 nM
Estimate against measurement, compound 3: 1.2-fold (0.08 log units) below, within the range that was stated.
By their numbers in this assay, from the lowest: compound 2; then compound 1; then compound 3.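

Going by these compounds alone, replacing 6-(methoxycarbonyl)pyridin-2-yl with 6-carboxypyridin-2-yl gives a 3.8-fold higher number from compound 1 to compound 3 (0.57 log units; beyond the scatter) in this assay, the first reading of this change. The loss is modest but beyond the scatter, and compound 3 still gives a measurable 120 nM with the carboxy group in this place. No evidence at hand bears on why the number rises.

Open, as far as these compounds go, is whether an amide or a hydroxymethyl group here would lie nearer compound 1 or compound 3. Also open, from the compounds shown here alone, is whether the step keeps its size with other chains on the shared core.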